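The compounds below may be only part of what the source reports. "The series", "measured", "known", "first", "only" and "open" are said of these compounds alone.

This study compares a small set of closely related compounds in an ADME assay for pharmacokinetics, in phosphate buffer, with a stated time of 30 min, at pH 7.4, tested at 1 mM, at a dose of 1 mM, in the absence of a further agent; on this read-out higher numbers stand for higher exposure at the dose given and lower numbers for lower exposure. Compound 1, with the structure `COc1ccc(C(=S)NCc2ccccc2)cc1`, is the starting point of the step followed here. In this assay compound 1 gives "not determined" (no result reported), so no number is available for it, and nothing can be said about where it stands against the others. Among the compounds with values here, compound 2, with the structure `N=C(SCc1ccccc1)c1cccs1`, is the only member of the set that carries a number: in this assay compound 2 gives 1900 nM. Compound 3, with the structure `N=C(Sc1ccccc1)c1ccc(O)cc1`, also lacks a result, as in this assay compound 3 gives "not determined" (no result reported).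

The compound still to be measured is compound 4, with the structure `Oc1ccc(C(=S)NCc2ccccc2)cc1`. It differs from compound 1 in one place: hydrogen in place of methyl on an oxygen on an aromatic ring. Within the data shown here, no pair of measured compounds shows this change, so the size of the step in this assay cannot be read from the data; the expectation is that it stays within the scatter, with no clear direction either way. Compound 4 is therefore expected to give about 1900 nM, with a range from 500 nM to 7000 nM. Among the measured compounds shown here, this expectation rests only on the single number in the set, the result of compound 2 at 1900 nM, and is accordingly wide.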

Compound 4, maximal plasma concentration: < 300 nM
Compound 4 ended at the assay's limit; the forecaster's own chance of this, stated with the estimate: 20%; middle value at least 6.3-fold (0.80 log units) away from the limit.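

Within the data shown here, no step from compound 1 to compound 4 can be read from these results. In this assay compound 4 gives < 300 nM, which is a limit of the assay and not a number. The compounds shown leave open how far the change from methoxy to hydroxy moves exposure, and in which direction.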